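From an Unsaturated to a Saturated Chain on a Shared Core

This account rests on a few compounds, and the source may have more. Where it says the series, first, only, none or still open, it means among the compounds named here.

In a functional assay on HeLa cells (Homo sapiens) for cytotoxicity, read by MTT assay, with a stated time of 24 h (a higher number here means a weaker inhibitor, a lower number a stronger inhibitor), compound 1 `CCCCCCCC/C=C\CCCCCCCC(=O)Nc1nnc(S[C@@H]2O[C@H](COC(C)=O)[C@H](OC(C)=O)[C@H](OC(C)=O)[C@H]2OC(C)=O)s1` gives 54400 nM and compound 2 `CCCCCCCC/C=C\CCCCCCCCCCCC(=O)Nc1nnc(S[C@@H]2O[C@H](COC(C)=O)[C@H](OC(C)=O)[C@H](OC(C)=O)[C@H]2OC(C)=O)s1` gives 58500 nM, which places compound 2 within the scatter of compound 1. Compound 3 `CCCCCCCCCCCCCCCCCC(=O)Nc1nnc(S[C@@H]2O[C@H](COC(C)=O)[C@H](OC(C)=O)[C@H](OC(C)=O)[C@H]2OC(C)=O)s1` keeps the shared core but has not yet been measured. It departs from compound 2 through (hexyl in place of dec-1-en-1-yl on a saturated chain carbon, ten or more bonds along the chain from a carbonyl carbon). Among the compounds with values here, no measured step shows the effect of this change, and no step beyond the scatter is expected in this assay. The expected step is a 1.0-fold higher number from compound 2 to compound 3 (0.01 log units; within the scatter). The estimate for compound 3 is 60000 nM, with an expected range of 33000 nM to 105000 nM.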

Compound 3, half-maximal inhibitory concentration: 97500 nM
Compound 3: the middle estimate sits 1.6-fold (0.21 log units) below what was measured, and the stated range covers the measured number.
By their numbers in this assay, from the lowest: compounds 1, 2 and 3 (each within the scatter of the next).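

Hexyl in place of dec-1-en-1-yl gives a 1.7-fold higher number from compound 2 to compound 3 (0.22 log units; within the scatter) and decyl in place of dec-1-en-1-yl gives a 1.8-fold higher number from compound 1 to compound 3 (0.25 log units; within the scatter) in this assay on the shared core. The fully saturated chain of compound 3 thus stays within the scatter of both unsaturated chains, which compounds 1 and 2 alone could not show. No measured evidence accompanies these numbers to explain them.

From the compounds shown here alone, whether an amine, a carboxylic acid or a much shorter chain in place of the hexyl would give a step beyond the scatter remains open.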